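The source may report more compounds than this note shows. Statements on the series, on what has been measured and on what is new or still open speak of the compounds shown alone.

Measured in a functional assay on DWD cells (Homo sapiens) for inhibition, read by sulforhodamine B assay; on this read-out lower numbers stand for stronger inhibition of growth and higher numbers for weaker inhibition of growth:
Compound 1 `Cc1ccc2[nH]c(-c3ccc(-c4ccc(-c5ccc(N(C)C)cc5)cc4)cc3)nc2c1`: 3230 nM
Compound 2 `Oc1cccc2[nH]c(-c3ccc(-c4ccc(-c5ccccc5)cc4)cc3)nc12`: 9680 nM
Compound 3 `COc1ccc(-c2ccc(-c3ccc(-c4nc5c(O)cccc5[nH]4)cc3)cc2)cc1`: 6400 nM

Compound 3, at 6400 nM, lies within the scatter of both other compounds in this assay. The next compound to read is compound 4 `CN(C)c1ccc(-c2ccc(-c3ccc(-c4nc5c(O)cccc5[nH]4)cc3)cc2)cc1`, which differs from compound 3 as follows: dimethylamino in place of methoxy on an aromatic carbon. In words, this is dimethylamino in place of methoxy on an aromatic carbon.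

Within the data shown here, no measured step makes this exchange. The nearest evidence is a 1.5-fold lower number from compound 2 to compound 3 (0.18 log units; within the scatter), which introduces the methoxy and stays within the scatter. Compound 1 also carries 4-(dimethylamino)phenyl, but on a different core, so it offers only indirect support. Its value of 3230 nM is still within the scatter of the value for compound 3. No step beyond the scatter is therefore expected in this assay, with at most a slight shift towards the number for compound 1.

The step expected is a 1.3-fold lower number from compound 3 to compound 4 (0.11 log units; within the scatter).
The estimated value for compound 4 is 5000 nM, with an expected range of 2200 nM to 11000 nM.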

Compound 4, concentration for 50% growth inhibition: 9210 nM
Beside the measured number, compound 4's estimate is 1.8-fold (0.27 log units) below it, within the range that was stated.
By their numbers in this assay, from the lowest: compounds 1, 3, 4 and 2 (each within the scatter of the next, the first and the last beyond it).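

In this assay, going from 4-methoxyphenyl to 4-(dimethylamino)phenyl gives a step within the scatter (a 1.4-fold higher number from compound 3 to compound 4 (0.16 log units; within the scatter)), and dimethylamino in place of hydrogen does the same (a 1.1-fold lower number from compound 2 to compound 4 (0.02 log units; within the scatter)), so with 4-hydroxy-1H-benzimidazol-2-yl held constant, hydrogen, methoxy and dimethylamino are not separated at this position. Among these compounds, the one new step beyond the scatter comes from the other change, 4-hydroxy-1H-benzimidazol-2-yl in place of 5-methyl-1H-benzimidazol-2-yl with dimethylamino kept, and it is modest (a 2.9-fold higher number from compound 1 to compound 4 (0.46 log units; beyond the scatter)). No measurement at hand bears on the reason for either outcome.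

Going by these compounds, whether a carboxylic acid, a primary amine or a longer alkoxy chain at this position would give a step beyond the scatter remains open. Also open, on these data alone, is whether the 5-methyl-1H-benzimidazol-2-yl exchange holds with hydrogen or methoxy in place of dimethylamino.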